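Carboxy for Methyl on a Boron-Bearing Chalcone Scaffold

This account rests on a few compounds, and the source may have more. Where it says the series, first, only, none or still open, it means among the compounds named here.

Two compounds from this series have a number in a functional assay on MDA-MB-231 cells (Homo sapiens) for cytotoxicity, read by MTT assay, with a stated time of 48 h; a higher number here means a weaker inhibitor, a lower number a stronger inhibitor. Compound 1 `O=C(/C=C/c1ccc2c(c1)B(O)OC2)c1cccnc1` gives 11400 nM in this assay. For the measured compounds named here, compound 2 `Cc1ccc(C(=O)/C=C/c2ccc3c(c2)B(O)OC3)cc1` gives 6500 nM in this assay, the lower of the two numbers, though the single measured step of a 1.8-fold lower number from compound 1 to compound 2 (0.24 log units; within the scatter) lies within the scatter, so the two compounds cannot be separated on the numbers alone.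

Compound 3 `O=C(O)c1ccc(C(=O)/C=C/c2ccc3c(c2)B(O)OC3)cc1` is not yet measured. It differs from compound 2 by carboxy in place of methyl on an aromatic carbon. No measured step concerns a substituent on this ring: the only step shown, from compound 1 to compound 2, exchanged the whole aryl group on the carbonyl carbon and stayed within the scatter. There is therefore no measured guide to the effect of a carboxy group at this place, and no direction can be read from the data.

In the absence of a relevant step, the expectation for compound 3 is a number near that of compound 2, with a wide range, and the step of a 1.4-fold higher number from compound 2 to compound 3 (0.14 log units; within the scatter) is expected to stay within the scatter. Compound 3 is estimated at 9000 nM in this assay, between 3000 nM and 30000 nM.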

Compound 3, half-maximal inhibitory concentration: > 100000 nM
Compound 3: no number, only a limit; the forecaster's own chance of this, stated with the estimate: 10%; middle value at least 11-fold (1.04 log units) from the limit.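

Carboxy in place of methyl on this aromatic carbon, para to a large group, gives an at least 15-fold higher number from compound 2 to compound 3 (1.18 log units; beyond the scatter) in this assay, and it is the only step shown that lies beyond the scatter. Compound 3 has no number, only a limit of the assay: the limit of > 100000 nM in this assay, at which 1 of the 3 values shown sits. The earlier exchange of the whole aryl group on the carbonyl carbon stayed within the scatter, whereas here a change of one substituent on that aryl ring clearly separates two compounds, so this place is not indifferent to what it carries in this assay.

The three compounds shown cannot tell whether the same step would appear with a methyl ester, a primary amide or a hydroxymethyl group at this place, which would show whether it is tied to the carboxy group itself. They also leave open how an amine, a methoxy group or a chlorine atom would read here, and whether any group at this place gives a lower number than methyl does.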